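Replacing a cyclic amine with isopropyl: cytotoxicity outlook

This account rests on a few compounds, and the source may have more. Where it says the series, first, only, none or still open, it means among the compounds named here.

Compound 1 `CN1CCC(Cn2c(N)nc3ccc(C(=O)c4ccccc4)cc32)CC1`; compound 2 `Nc1nc2ccc(C(=O)c3ccccc3)cc2n1C[C@@H]1CCCN1`; compound 3 `CN1CCC[C@@H]1Cn1c(N)nc2ccc(C(=O)c3ccccc3)cc21`.

In an ADME assay on CRL8155 cells (Homo sapiens) for cytotoxicity, read by resazurin assay, with a stated time of 72 h (a higher number here means that more compound is needed for the effect, a lower number that less compound is needed), compound 1 gives > 30000 nM, which is a limit of the assay rather than a number. In this assay compound 2 gives > 30000 nM, also a limit. Compound 3 gives > 30000 nM, again a limit. Compound 3 thus stands at the limit of > 30000 nM in this assay, at which 3 of the 3 values shown sit, indistinguishable from the others. The steps a step that the two limits leave unreadable from compound 1 to compound 2, a step that the two limits leave unreadable from compound 1 to compound 3 and a step that the two limits leave unreadable from compound 2 to compound 3 accordingly have no readable size. Compound 4 `CC(C)Cn1c(N)nc2ccc(C(=O)c3ccccc3)cc21` differs from compound 3 in this way: isopropyl in place of 1-methylpyrrolidin-2-yl on a saturated chain carbon bound to an aromatic nitrogen. The measured steps alter the same place but never to isopropyl, and all sit at the limit, so no direction can be read. The step from compound 3 is expected to be a number no higher from compound 3 to compound 4 (the limit leaves the size open). Compound 4 is therefore expected to give about 30000 nM, between 10000 nM and 100000 nM, most likely reported once more as a limit.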

Compound 4, half-maximal effective concentration: > 30000 nM
Compound 4: no number, only a limit; the forecaster's own chance of this, stated with the estimate: 85%; the middle value lies on the limit itself.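

In this assay compound 4 gives > 30000 nM, again a limit of the assay and not a number. Its steps from compound 1, compound 2 and compound 3 cannot be read. On these data alone, how much of any of these four compounds is needed for the effect stays open, and so does whether the group at this place matters at all.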